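Swapping the methylamino of compound 2 for cyclopentyl

This account rests on a few compounds, and the source may have more. Where it says the series, first, only, none or still open, it means among the compounds named here.

Measured compounds:
- compound 1 `C=Cc1cn2ncc(-c3ccnc(OC)c3)c2nc1NC`: 190 nM
- compound 2 `CNc1nc2c(-c3ccnc(OC)c3)cnn2cc1OC`: 310 nM
- compound 3 `CNc1nc2c(-c3ccnc(OC)c3)cnn2cc1C1CC1`: 630 nM

These three share one core and differ only at a single aromatic carbon carrying vinyl, methoxy or cyclopropyl. In an assay on isolated protein for inhibition of activin receptor type-2A (Homo sapiens), read by 33P incorporation, with a stated time of 20 min, in the presence of a further agent that is not named here (a higher number here means a weaker inhibitor, a lower number a stronger inhibitor), compound 2 stands in the middle: against compound 1 the step is a 1.6-fold higher number from compound 1 to compound 2 (0.21 log units; within the scatter), which is within the scatter, while against compound 3 the step is a 2.0-fold higher number from compound 2 to compound 3 (0.31 log units; beyond the scatter). Compound 4 `COc1cc(-c2cnn3cc(OC)c(C4CCCC4)nc23)ccn1` is built from compound 2 by a different kind of change: cyclopentyl in place of methylamino on an aromatic carbon. Among the measured compounds shown here, none of the measured steps touches this position; all three measured compounds keep the methylamino untouched, so there is no measured step that bears directly on the move to cyclopentyl. For the measured compounds named here, the expectation therefore rests only on the size of the change itself, which removes the one donor-bearing group on the core and puts in a larger ring of carbon. For compound 4 in this assay a weaker result is expected, with a step of a 4.8-fold higher number from compound 2 to compound 4 (0.68 log units; beyond the scatter). The estimate for compound 4 is 1500 nM, within a range of 400 nM to 6000 nM.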

Compound 4, half-maximal inhibitory concentration: 2900 nM
Estimate against measurement, compound 4: 1.9-fold (0.29 log units) below; measured number inside the range.
By their numbers in this assay, from the lowest: compounds 1 and 2 (each within the scatter of the next); then compound 3; then compound 4.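

Moving from the aromatic carbon that varies among the first three compounds to the one carrying methylamino, the first measured change at this position in this assay is a 9.4-fold higher number from compound 2 to compound 4 (0.97 log units; beyond the scatter), so the inhibition read here does respond to the group at this position. The swap replaces a group with one hydrogen-bond donor and one acceptor by a cyclopentyl ring with neither, and compound 4 still gives a measurable number rather than losing all inhibition. Nothing available explains why the number rises at this position.

Donor, acceptor, ring and size all change together in this one swap, so their separate contributions remain unknown. On these data alone, a cyclopentylamino or ethylamino group at this carbon would keep the donor while adding carbon, and whether cyclopentyl has the same effect alongside vinyl or cyclopropyl also remains open.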